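Cytotoxicity notes: a larger amine substituent on compound 3

The compounds below may be only part of what the source reports. "The series", "measured", "known", "first", "only" and "open" are said of these compounds alone.

In a functional assay on MT4 cells (Homo sapiens) (on this read-out lower numbers stand for higher toxicity in this test and higher numbers for lower toxicity in this test), compound 3 `COC(=O)NC1=CS(=O)(=O)O[C@@]12[C@@H](CO[Si](C)(C)C(C)(C)C)O[C@@H](n1cc(C)c(=O)n(C)c1=O)[C@@H]2O[Si](C)(C)C(C)(C)C` gives 29900 nM, level within the scatter with compound 1 `Cc1cn([C@@H]2O[C@H](CO[Si](C)(C)C(C)(C)C)[C@@]3(OS(=O)(=O)C=C3NCC(=O)O)[C@H]2O[Si](C)(C)C(C)(C)C)c(=O)n(C)c1=O` at 30000 nM. Compound 2 `Cc1cn([C@@H]2O[C@@H]3COC(=O)[C@]3(OS(C)(=O)=O)[C@H]2O)c(=O)[nH]c1=O` gives only a limit, >= 250000 nM.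

Compound 4 `Cc1cn([C@@H]2O[C@H](CO[Si](C)(C)C(C)(C)C)[C@@]3(OS(=O)(=O)C=C3NCCC(=O)OCc3ccccc3)[C@H]2O[Si](C)(C)C(C)(C)C)c(=O)n(C)c1=O` differs from compound 3 as follows: 2-(benzyloxycarbonyl)ethyl in place of methoxycarbonyl on an amine nitrogen. This places 2-(benzyloxycarbonyl)ethyl in place of methoxycarbonyl on an amine nitrogen. Going by the values given here, only one measured change falls on this nitrogen, methoxycarbonyl in place of carboxymethyl: a 1.0-fold lower number from compound 1 to compound 3 (0.00 log units; within the scatter). No shift beyond the scatter is therefore expected, though this rests on a single step and the entering group is larger. The expected change is a 1.2-fold lower number from compound 3 to compound 4 (0.08 log units; within the scatter). Compound 4 is estimated at 25000 nM, with an expected range of 10000 nM to 60000 nM.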

Compound 4, half-maximal cytotoxic concentration: > 250000 nM
Compound 4: only a limit was reported; the forecaster's own chance of this, stated with the estimate: 10%; at least 10-fold (1.00 log units) between middle value and limit.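

The amine nitrogen is not indifferent to its substituent, as the earlier step between compound 1 and compound 3 alone suggested: in this assay there is an at least 8.3-fold higher number from compound 3 to compound 4 (0.92 log units; beyond the scatter), and likewise an at least 8.3-fold higher number from compound 1 to compound 4 (0.92 log units; beyond the scatter). Both steps point to lower toxicity in this test with the entering benzyl ester. The figure for compound 4 is a limit, so the true size of both steps stays unknown: the limit of > 250000 nM in this assay, at which 1 of the 4 values shown sits.

On these data alone, whether the aromatic ring or the longer chain carries the shift remains open. A 2-carboxyethyl or plain benzyl group on the same nitrogen would separate the two.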